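The compounds below may be only part of what the source reports. "The series", "measured", "known", "first", "only" and "open" are said of these compounds alone.

Measured compounds and their values:

- compound 1 `C=CCn1ccc(N2C[C@H](CO)OC2=O)c1`: 625000 nM in an assay for inhibition of Amine oxidase [flavin-containing] B (Bos taurus), read by fluorescence, with a stated time of 30 min; on this read-out higher numbers stand for weaker inhibition and lower numbers for stronger inhibition
- compound 2 `COC[C@H]1CN(c2ccn(C)c2)C(=O)O1`: 170000 nM
- compound 3 `CCn1ccc(N2C[C@H](COC)OC2=O)c1`: 1300 nM

Compound 3 gives the lowest number of the three, so on this read-out it is the strongest inhibitor shown; compound 2 is nearest to it and compound 1 furthest, both gaps lying beyond the scatter. Within the data shown here, the only single-point step among the measured compounds is a 130-fold lower number from compound 2 to compound 3 (2.12 log units; beyond the scatter), a large gain from lengthening the chain on the ring nitrogen.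

Compound 4 `C=CCn1ccc(N2C[C@H](COC)OC2=O)c1` differs from compound 3 by vinyl in place of methyl on a saturated chain carbon bound to an aromatic nitrogen. Among the measured compounds shown here, no measured pair shows exactly this change. Compound 1 also carries the allyl group but differs from compound 3 in a second place as well, so its high number cannot be read as the effect of the allyl alone. For the measured compounds named here, the one relevant step, from compound 2 to compound 3, shows that growing this chain helped, while compound 1 warns that the allyl chain does not guarantee strong inhibition. The expectation for compound 4 is therefore a small step, a 1.5-fold higher number from compound 3 to compound 4 (0.19 log units; within the scatter), with wide uncertainty; compound 4 is estimated at 2000 nM, between 200 nM and 20000 nM.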

Compound 4, inhibition constant: 200000 nM
Compound 4: middle estimate off by 100-fold (2.00 log units), on the low side, and the stated range ends below it.
By their numbers in this assay, from the lowest: compound 3; then compounds 2 and 4 (each within the scatter of the next); then compound 1.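

In this assay, among these compounds, the chain on the ring nitrogen proves far less forgiving than the earlier compounds suggested: going from ethyl to allyl gives a 150-fold higher number from compound 3 to compound 4 (2.19 log units; beyond the scatter), which removes the whole gain seen with ethyl. The comparison with the methyl compound gives a 1.2-fold higher number from compound 2 to compound 4 (0.07 log units; within the scatter), so the longer chain does not itself bring stronger inhibition, and among these three chains only ethyl gives a low number. With allyl kept in place, methyl in place of hydrogen on the oxygen gives only a 3.1-fold lower number from compound 1 to compound 4 (0.49 log units; beyond the scatter), a modest step beside the one from ethyl to allyl.

Nothing available here explains why ethyl and allyl differ so sharply. On these data alone, whether a propyl chain, the saturated counterpart of allyl, would behave like ethyl or like allyl remains open.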